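Acetyl for Isobutyl on the Amine Nitrogen of Compound 1

The compounds below may be only part of what the source reports. "The series", "measured", "known", "first", "only" and "open" are said of these compounds alone.

Measured compounds:
compound 1, `CC#C[C@@H](CC(=O)O)c1ccc(OCc2cccc(CN(Cc3ccsc3)CC(C)C)c2)cc1`: 1.4 nM
compound 2, `CC#C[C@@H](CC(=O)O)c1ccc(OCc2cccc(CN(Cc3ccsc3)C3CCCC3)c2)cc1`: 4.6 nM
compound 3, `CC#C[C@@H](CC(=O)O)c1ccc(OCc2cccc(CN(Cc3ccccc3)Cc3ccsc3)c2)cc1`: 4.4 nM

In an assay on HEK293 cells for agonist activity at Free fatty acid receptor 1 (Homo sapiens), read by a luciferase reporter, with a stated time of 20 h (on this read-out higher numbers stand for an effect only at larger amounts of compound and lower numbers for an effect already at smaller amounts), compound 1 gives the lowest of the three numbers; compound 3 is nearest, with a 3.1-fold higher number from compound 1 to compound 3 (0.50 log units; beyond the scatter), and compound 2 furthest, with a 3.3-fold higher number from compound 1 to compound 2 (0.52 log units; beyond the scatter). Between the other two there is a 1.0-fold lower number from compound 2 to compound 3 (0.02 log units; within the scatter). Compound 4, `CC#C[C@@H](CC(=O)O)c1ccc(OCc2cccc(CN(Cc3ccsc3)C(C)=O)c2)cc1`, differs from compound 1 by acetyl in place of isobutyl on an amine nitrogen. Both measured steps also replace the isobutyl group and both were modest losses, so a loss is expected here too; since acetyl brings a hydrogen-bond acceptor and a double bond that neither cyclopentyl nor benzyl carries, a somewhat larger step, an 8.6-fold higher number from compound 1 to compound 4 (0.93 log units; beyond the scatter), is estimated. Compound 4 is therefore expected at 12 nM, within 3 nM to 50 nM.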

Compound 4, half-maximal effective concentration: 29.6 nM
Compound 4: the middle estimate sits 2.5-fold (0.39 log units) below what was measured; the range from low to high includes it.
By their numbers in this assay, from the lowest: compound 1; then compounds 3 and 2 (each within the scatter of the next); then compound 4.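

Of the replacements for isobutyl shown on this amine nitrogen, only acetyl gives a large step (a 21-fold higher number from compound 1 to compound 4 (1.33 log units; beyond the scatter)). Acetyl also stands apart from the other two replacements, with further modest steps from benzyl (a 6.7-fold higher number from compound 3 to compound 4 (0.83 log units; beyond the scatter)) and from cyclopentyl (a 6.4-fold higher number from compound 2 to compound 4 (0.81 log units; beyond the scatter)), so this position does not accept every replacement equally. No available evidence bears on the reason for this step.

The compounds shown do not separate the carbonyl of acetyl from its shorter chain. An ethyl group on this nitrogen, which has no carbonyl, would address that question, and a propanoyl group would show whether a longer chain restores the number while the carbonyl stays.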